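Antiproliferative series: exchanging the amide acyl group

The compounds below may be only part of what the source reports. "The series", "measured", "known", "first", "only" and "open" are said of these compounds alone.

Measured so far in a functional assay on ID8 cells (Mus musculus) for antiproliferative activity; on this read-out lower numbers stand for stronger inhibition and higher numbers for weaker inhibition
compound 1 `O=C(Nc1ccc(O)c2c(=O)cc(-c3ccccc3Cl)oc12)c1ccc(Cl)c(Cl)c1` gives 13000 nM
compound 2 `O=c1cc(-c2ccccc2Cl)oc2c(N3CCCC3)ccc(O)c12` gives 9300 nM

Compound 1 stands level with compound 2 on these numbers: the two values lie within the scatter of each other, so they set no order. Among the compounds with values here, no pair of measured compounds differs in one place only, so the data hold no direct measure of a change at this carbonyl. Compound 3 `C[C@@H](NC(=O)OC(C)(C)C)C(=O)Nc1ccc(O)c2c(=O)cc(-c3ccccc3Cl)oc12` keeps the core of compound 1, with 1-((tert-butoxycarbonyl)amino)ethyl in place of 3,4-dichlorophenyl on a carbonyl carbon. Since compound 2 gives 9300 nM with a different structure, within the scatter of compound 1, no shift beyond the scatter is expected in this assay for this exchange. The expected step is a 1.3-fold lower number from compound 1 to compound 3 (0.11 log units; within the scatter), which is no real change. Compound 3 is estimated at 10000 nM, with an expected range of 3500 nM to 30000 nM.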

Compound 3, half-maximal inhibitory concentration: 104000 nM
Beside the measured number, compound 3's estimate is 10-fold (1.02 log units) below it; measured number above the stated range.
By their numbers in this assay, from the lowest: compounds 2 and 1 (each within the scatter of the next); then compound 3.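

Within the data shown here, the exchange of 3,4-dichlorophenyl for 1-((tert-butoxycarbonyl)amino)ethyl on a carbonyl carbon gives the first single-place comparison in this assay, with an 8.0-fold higher number from compound 1 to compound 3 (0.90 log units; beyond the scatter), so this position is not indifferent to the group it carries. Compounds 1 and 2 set no order and differ in more than one place, whereas this pair shows weaker inhibition with the open-chain group than with 3,4-dichlorophenyl. Nothing on hand accounts for this shift.

The exchange removes the aromatic ring and changes size, hydrogen-bond donor and acceptor counts and stereocentre count all at once, so the pair cannot show which of these differences matters. A free amine in place of the tert-butoxycarbonyl-protected amine, a carboxylic acid, or an unsubstituted phenyl on this carbonyl carbon would help separate these differences.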